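The compounds below may be only part of what the source reports. "The series", "measured", "known", "first", "only" and "open" are said of these compounds alone.

Compound 1 `Clc1ccc2[nH]c(-c3cn(-c4ccccc4)nc3-c3ccccc3)nc2c1`: 1960 nM
Compound 2 `Clc1ccc(-c2nn(-c3ccccc3)cc2-c2nc3ccccc3[nH]2)cc1`: 3030 nM

In a functional assay on MCF7 cells (Homo sapiens) for antiproliferative activity, read by MTT assay, with a stated time of 48 h (a lower number here means a stronger inhibitor, a higher number a weaker inhibitor), compound 2 gives 3030 nM. Compound 1 gives 1960 nM, which lies within the usual scatter of compound 2, so the measurements do not separate the two. Compound 3 `Clc1ccc(-c2nn(-c3ccccc3)cc2-c2nc3cc(Cl)ccc3[nH]2)cc1` is compound 2 with one change, chloro in place of hydrogen on an aromatic carbon. Within the data shown here, no measured pair shows this change alone. Compound 1 also carries a chloro at this place and gives 1960 nM, so only a small move towards a lower number is expected in this assay, none beyond the scatter. The expected change is a 1.4-fold lower number from compound 2 to compound 3 (0.14 log units; within the scatter). For compound 3 the estimated value is 2200 nM, with an expected range of 900 nM to 5500 nM.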

Compound 3, half-maximal inhibitory concentration: 1170 nM
For compound 3 the middle estimate is 1.9-fold (0.27 log units) above the measured one; low and high end bracket the measured number.
By their numbers in this assay, from the lowest: compounds 3, 1 and 2 (each within the scatter of the next, the first and the last beyond it).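

In this assay, chloro in place of hydrogen on an aromatic carbon of the fused system of two rings gives a 2.6-fold lower number from compound 2 to compound 3 (0.41 log units; beyond the scatter) and so makes a real difference at this position. The other chloro, which compound 3 carries and compound 1 lacks, gives a 1.7-fold lower number from compound 1 to compound 3 (0.22 log units; within the scatter) and does not separate those two compounds. Nothing measured here explains either step. From the compounds shown here alone, whether fluoro, bromo, methyl or an amine at the same place would match chloro remains open.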